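A few compounds are considered here, and "the series" means these few. Any claim that something is new, unique, unknown or untested is made for them only; others in the source may bear on it.

Measured so far in a functional assay on HT-29 cells (Homo sapiens) for inhibition, read by MTT assay, with a stated time of 72 h; a higher number here means a weaker inhibitor, a lower number a stronger inhibitor:
Compound 1 `COc1ccc(CNCc2c(OC)cc(Oc3cccc(Nc4ccccc4)c3)cc2OC)cc1` gives 1890 nM.
Compound 2 `COc1cc(Oc2cccc(Nc3ccccc3)c2)cc(OC)c1CNCc1ccccc1` gives 3340 nM.
Compound 3 `COc1cc(Oc2cccc(Nc3ccccc3)c2)cc(OC)c1CNCc1ccc(F)cc1` gives 2750 nM.

Compound 3 stands second highest of the three numbers, nearest compound 2 and furthest from compound 1; both gaps, a 1.2-fold lower number from compound 2 to compound 3 (0.08 log units; within the scatter) and a 1.5-fold higher number from compound 1 to compound 3 (0.16 log units; within the scatter), lie within the scatter, as does a 1.8-fold higher number from compound 1 to compound 2 (0.25 log units; within the scatter). The three compounds therefore read as equivalent in this assay.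

Compound 4 `CNCc1c(OC)cc(Oc2cccc(Nc3ccccc3)c2)cc1OC` carries the change (hydrogen in place of 4-fluorophenyl on a saturated chain carbon bound to an amine nitrogen). No measured step bears directly on this: the steps shown only exchange the group on the 4-fluorophenyl ring, leaving the ring itself in place, and none of them moved the number beyond the scatter. Removal of the whole ring is untested in the series, so the direction is open; the size of step in this assay is expected to be small to moderate, most likely a somewhat higher number, with a wide range either way.

Compound 4 is expected to give about 4500 nM in this assay, between 1500 nM and 15000 nM. That expectation corresponds to a 1.6-fold higher number from compound 3 to compound 4 (0.21 log units; within the scatter).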

Compound 4, half-maximal inhibitory concentration: 7430 nM
Estimate against measurement, compound 4: 1.7-fold (0.22 log units) below, within the range that was stated.
By their numbers in this assay, from the lowest: compounds 1, 3 and 2 (each within the scatter of the next); then compound 4.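

Working from this assay, replacing the 4-fluorophenyl, phenyl or 4-methoxyphenyl ring on the saturated chain carbon bound to an amine nitrogen with hydrogen gives a 2.7-fold higher number from compound 3 to compound 4 (0.43 log units; beyond the scatter) and a 2.2-fold higher number from compound 2 to compound 4 (0.35 log units; beyond the scatter) and a 3.9-fold higher number from compound 1 to compound 4 (0.59 log units; beyond the scatter) as the first steps in the series to pass beyond the scatter. All three run the same way, whereas exchanges of the group on the ring among compounds 1, 2 and 3 stayed within the scatter, so in these four compounds removing the ring counts for more than changing what it carries. Nothing available accounts for this step.

The compounds shown leave open whether an aromatic ring is needed here or whether a cyclohexyl ring or a longer chain on the amine would serve equally. On these data alone, how a pyridine ring in place of the phenyl ring would read also remains open.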